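This account rests on a few compounds, and the source may have more. Where it says the series, first, only, none or still open, it means among the compounds named here.

Measured so far in an ADME assay on HEp-2 cells (Homo sapiens) for cytotoxicity, read by CCK-8 assay, with a stated time of 5 days; a higher number here means that more compound is tolerated, a lower number that less compound is tolerated:
compound 1, `NCCNc1cc(N2CCCc3ccccc3C2)nc2c(Cl)cccc12`, gives 25000 nM;
compound 2, `CS(=O)(=O)c1ccc2nc(N3CCCc4ccccc4C3)cc(NCCN)c2c1`, gives 13000 nM;
compound 3, `CNCCNc1cc(N2CCCc3ccc(F)cc3C2)nc2ccc(C)cc12`, gives 29000 nM.

Among these three numbers compound 3 stands highest. Its value and the value of compound 1 lie within the usual scatter of repeated measurements, so no order can be read between them. Compound 2 shows a lower number than compound 3, and that gap is beyond the scatter. Within the data shown here, none of the measured compounds differ from one another in just one place, so no single-change comparison is available from them.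

Compound 4, `CC(=O)NCCNc1cc(N2CCCc3ccc(F)cc3C2)nc2ccc(C)cc12`, differs from compound 3 in one place: acetyl in place of methyl on an amine nitrogen. Cut one bond further out, the exchange reads methylamino to acetamido. Among the measured compounds shown here, no measured pair shows this exchange, so the expectation rests on compound 3 alone. In this assay a small step upward, or none beyond the scatter, is expected. Compound 4 is therefore expected to give 35000 nM, within a range from 15000 nM to 80000 nM. This estimate means an expected step of a 1.2-fold higher number from compound 3 to compound 4 (0.08 log units; within the scatter).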

Compound 4, half-maximal cytotoxic concentration: 66000 nM
Compound 4: the middle estimate sits 1.9-fold (0.28 log units) below what was measured; low and high end bracket the measured number.
By their numbers in this assay, from the lowest: compounds 2, 1 and 3 (each within the scatter of the next, the first and the last beyond it); then compound 4.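

In this assay, exchanging methyl for acetyl on an amine nitrogen, which turns methylamino into acetamido, gives a 2.3-fold higher number from compound 3 to compound 4 (0.36 log units; beyond the scatter). Among these compounds, this is the first comparison here in which only one place changes, and it shows that the group on this nitrogen can move the tolerated concentration beyond the usual scatter while the shared core stays the same. No measurement shown explains the rise, and a single pair cannot establish a general pattern.

Going by these compounds, it remains open whether an ethyl group on this nitrogen, which would have no carbonyl, would give a number closer to compound 3 or to compound 4. A longer acyl chain such as propionyl, or a methanesulfonyl group in place of acetyl, could also show whether the step is specific to acetyl.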